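The compounds below may be only part of what the source reports. "The series", "measured", "known", "first", "only" and "open" are said of these compounds alone.

Measured so far in an assay on isolated protein for inhibition of myosin-2 (Bos taurus), read by spectrophotometry, with a stated time of 24 min; a lower number here means a stronger inhibitor, a higher number a weaker inhibitor:

compound 1 `C/C(=N\Cc1cccc(C)c1)c1c(O)c2ccccc2oc1=O`: 4900 nM
compound 2 `CC/C(=N\Cc1ccccc1)c1c(O)c2ccccc2oc1=O`: >= 100000 nM
compound 3 `CCC/N=C(\C)c1c(O)c2ccccc2[nH]c1=O`: >= 100000 nM

Compound 1 is the only one of the three with a number in this assay, giving 4900 nM. For compound 2 the assay reports no number but a limit, >= 100000 nM. For compound 3 the result is likewise a limit, >= 100000 nM. The two limits together make up (the limit of >= 100000 nM in this assay, at which 2 of the 3 values shown sit), so compound 1 stands apart simply by having a measurable result at all.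

Compound 4 `CCCCC/N=C(\C)c1c(O)c2ccccc2oc1=O` is not yet measured. Set against compound 1 it carries butyl in place of 3-methylphenyl on a saturated chain carbon bound to a double-bonded nitrogen. For the measured compounds named here, no two measured compounds differ in only one place, so no measured step tells how this assay responds to such a swap. Compound 3 also carries a plain chain on that carbon and reaches only a limit, though its core differs too, so it gives only a hint.

The expected result for compound 4 is 30000 nM, in a range from 8000 nM to 100000 nM. This estimate means a step of a 6.1-fold higher number from compound 1 to compound 4 (0.79 log units; beyond the scatter), a weakening beyond the usual scatter, with a real chance that only a limit is reported.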

Compound 4, half-maximal inhibitory concentration: 6700 nM
Beside the measured number, compound 4's estimate is 4.5-fold (0.65 log units) above it, outside the stated range (below it).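

In this assay, replacing the 3-methylphenyl with butyl on a saturated chain carbon bound to a double-bonded nitrogen gives a 1.4-fold higher number from compound 1 to compound 4 (0.14 log units; within the scatter). For this pair, then, the ring is not needed to keep the inhibition: a plain chain with no ring serves equally well, even though it brings fewer heavy atoms. Compound 4 also returns a real number rather than a limit, so it stays apart from the compounds that reach only the limit: the limit of >= 100000 nM in this assay, at which 2 of the 4 values shown sit.

The compounds shown leave open how much else this place accepts, such as a longer chain or a chain ending in an amine or a carboxylic acid. As far as these compounds go, compound 2 and compound 3 each differ from the others in more than one place, so their steps cannot be read, and what separates them from compound 1 and compound 4 remains unknown.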